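This account rests on a few compounds, and the source may have more. Where it says the series, first, only, none or still open, it means among the compounds named here.

Measured so far:
Compound 1, `Cc1ccc(-c2nn(-c3ccccc3)cc2C(=O)NOCc2ccccc2)cc1`, in a functional assay on HeLa cells (Homo sapiens) for antiproliferative activity, read by MTT assay, with a stated time of 48 h, in the presence of a further agent that is not named here (a higher number here means a weaker inhibitor of growth, a lower number a stronger inhibitor of growth), compound 1 gives 6690 nM.
Compound 2, `COc1ccc(-c2nn(-c3ccccc3)cc2C(=O)NOCc2ccccc2)cc1`, in this assay compound 2 gives 2640 nM.

Compound 2 has the lowest of the two numbers in this assay; its nearest neighbour is compound 1, separated by a 2.5-fold lower number from compound 1 to compound 2 (0.40 log units; beyond the scatter), a modest step that lies beyond the scatter.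

Compound 3, `O=C(NOCc1ccccc1)c1cn(-c2ccccc2)nc1-c1ccc(Cl)cc1`, is not yet measured. It differs from compound 2 by chloro in place of methoxy on an aromatic carbon. Within the data shown here, the only measured step at this position is the one from methyl to methoxy, a 2.5-fold lower number from compound 1 to compound 2 (0.40 log units; beyond the scatter), and it does not involve chloro, so no measured step bears directly on the change to compound 3. Chloro and methoxy are each a single substituent at the same place, and with the sole measured step being modest, no step beyond the scatter is expected in this assay; the estimate is set near compound 2 with a wide range. Compound 3 is therefore expected to give 3500 nM (range 1200 nM to 10000 nM), which means an expected step of a 1.3-fold higher number from compound 2 to compound 3 (0.12 log units; within the scatter).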

Compound 3, concentration for 50% growth inhibition: 8350 nM
Compound 3: middle estimate off by 2.4-fold (0.38 log units), on the low side, within the range that was stated.
By their numbers in this assay, from the lowest: compound 2; then compounds 1 and 3 (each within the scatter of the next).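

In this assay the change from 4-methoxyphenyl to 4-chlorophenyl gives a 3.2-fold higher number from compound 2 to compound 3 (0.50 log units; beyond the scatter) and so runs opposite in direction to the methyl-to-methoxy step, which gave a 2.5-fold lower number from compound 1 to compound 2 (0.40 log units; beyond the scatter) at the same place. Chloro in place of methyl gives a 1.2-fold higher number from compound 1 to compound 3 (0.10 log units; within the scatter) and sets no order between those two compounds, so among the three groups on this aromatic carbon, methoxy alone stands apart from the other two. No evidence at hand accounts for this difference.

Going by these compounds, whether the lower number is particular to methoxy or extends to other groups at this place, such as ethoxy, hydroxyl or an amine, remains open. Also open, on these data alone, is whether the same order among methoxy, methyl and chloro holds when another part of the shared core changes.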